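A Methyl Added to the Anilide Ring of Compound 1

This account rests on a few compounds, and the source may have more. Where it says the series, first, only, none or still open, it means among the compounds named here.

Measured so far:
Compound 1, `COc1ccc2c(=O)c(/C=C/C(=O)Nc3ccccc3)coc2c1`, in a functional assay on A549 cells (Homo sapiens) for inhibition, read by MTT assay, with a stated time of 48 h (a higher number here means a weaker inhibitor, a lower number a stronger inhibitor), gives 51000 nM.
Compound 3, `COc1cccc(NC(=O)/C=C/c2coc3cc(OC)ccc3c2=O)c1`, in this assay gives 12800 nM.
Compound 2, `O=C(/C=C/c1coc2cc(O)ccc2c1=O)NCc1ccccc1`, in this assay gives only the assay limit > 100000 nM, not a number.

For the measured compounds named here, of the two numbers, compound 1 has the highest; the only other number lies a 4.0-fold lower number from compound 1 to compound 3 (0.60 log units; beyond the scatter). Compound 4, `COc1ccc2c(=O)c(/C=C/C(=O)Nc3ccccc3C)coc2c1`, has not yet been measured. It differs from compound 1 by methyl in place of hydrogen on an aromatic carbon. Going by the values given here, the single measured step, a 4.0-fold lower number from compound 1 to compound 3 (0.60 log units; beyond the scatter), also placed a small group on an aromatic carbon of the same anilide ring, and was modest in size. A change of similar or smaller size is therefore expected here, a 1.7-fold lower number from compound 1 to compound 4 (0.23 log units; within the scatter). Compound 4 is estimated at 30000 nM, within a range from 10000 nM to 90000 nM.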

Compound 4, half-maximal inhibitory concentration: 23400 nM
Compound 4: the middle estimate sits 1.3-fold (0.11 log units) above what was measured; the measured number falls inside the stated range.
By their numbers in this assay, from the lowest: compounds 3 and 4 (each within the scatter of the next); then compound 1. At a limit, above all of these: compound 2.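

In this assay methyl ortho to a large group on the anilide ring gives a 2.2-fold lower number from compound 1 to compound 4 (0.34 log units; beyond the scatter) and so shows that compound 3 is not the only anilide with a substituent to move beyond the scatter. Placing 2-methylphenyl where 3-methoxyphenyl stood gives a 1.8-fold higher number from compound 3 to compound 4 (0.26 log units; within the scatter) and so leaves these two substituted rings unseparated. Nothing measured here explains either step.

Still open, on these data alone, is whether the group or its place on the ring matters more. An amine or a carboxylic acid on this ring, or methyl on another of its carbons, could help to separate the two.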